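The source may report more compounds than this note shows. Statements on the series, on what has been measured and on what is new or still open speak of the compounds shown alone.

For the measured compounds named here, compound 3 `O=C1N/C(=N/c2csc(-c3ccc(Cl)cc3)c2)S/C1=C\c1ccc2ccccc2c1` stands lowest of the three numbers so far in a functional assay on HT-29 cells (Homo sapiens) for cytotoxicity, read by MTT assay, with a stated time of 72 h (a lower number here means a stronger inhibitor, a higher number a weaker inhibitor), where compound 3 gives 3700 nM. Compound 1 `O=C1N/C(=N/c2csc(-c3ccc(Cl)cc3)c2)S/C1=C\c1ccccc1` gives 10500 nM in this assay, and compound 2 `Cc1ccc(/C=C2\S/C(=N\c3csc(-c4ccc(Cl)cc4)c3)NC2=O)cc1` gives 6400 nM. Compound 4 `O=C1N/C(=N/c2csc(-c3ccc(Cl)cc3)c2)S/C1=C\c1ccccn1` differs from compound 3 by pyridin-2-yl in place of naphthalen-2-yl on a double-bonded chain carbon bound to a double-bonded ring carbon. Going by the values given here, two measured steps bear on this change. The step of a 2.8-fold lower number from compound 1 to compound 3 (0.45 log units; beyond the scatter) shows that going from phenyl to naphthalen-2-yl at this place lowers the number modestly, beyond the scatter. The step of a 1.7-fold lower number from compound 2 to compound 3 (0.24 log units; within the scatter) is within the scatter. Compound 4 goes the other way, back to a single six-membered ring, one that now holds a nitrogen. Among the compounds with values here, no measured compound carries a ring with a hetero atom at this place. The number for compound 4 is therefore expected to move back up toward compound 1 with its 10500 nM, and the expected step is a 2.7-fold higher number from compound 3 to compound 4 (0.43 log units; beyond the scatter). Compound 4 is estimated at 10000 nM, with a range from 3500 nM to 30000 nM.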

Compound 4, half-maximal inhibitory concentration: 11500 nM
Estimate against measurement, compound 4: 1.2-fold (0.06 log units) below; the range from low to high includes it.
By their numbers in this assay, from the lowest: compounds 3, 2, 1 and 4 (each within the scatter of the next, the first and the last beyond it).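

In this assay, replacing naphthalen-2-yl with pyridin-2-yl gives up the modest gain seen with the two-ring group (a 3.1-fold higher number from compound 3 to compound 4 (0.49 log units; beyond the scatter)). Against the single rings, the ring nitrogen makes no readable difference: both a 1.1-fold higher number from compound 1 to compound 4 (0.04 log units; within the scatter) and a 1.8-fold higher number from compound 2 to compound 4 (0.25 log units; within the scatter) lie within the scatter. At this place, on a double-bonded chain carbon bound to a double-bonded ring carbon, pyridin-2-yl therefore cannot be told apart from phenyl or 4-methylphenyl, and no measurement at hand explains any of these steps. 

The compounds shown leave open whether moving the nitrogen within the ring, as in pyridin-3-yl, would change the number. They also leave open whether an amine or a carboxylic acid on the phenyl ring would shift it beyond the scatter.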